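Three Measured Compounds and a Fourth Awaiting Its Number

This account rests on a few compounds, and the source may have more. Where it says the series, first, only, none or still open, it means among the compounds named here.

Compound 1 `Fc1ccccc1NC(=S)Nc1cccc(C(F)(F)F)c1`: 64000 nM
Compound 2 `FC(F)(F)c1cccc(NC(=S)Nc2ccc(Cl)cc2)c1`: 11000 nM
Compound 3 `C=C(C)CNC(=S)Nc1cccc(C(F)(F)F)c1`: > 100000 nM

All three were tested in an ADME assay on Vero 76 cells (Chlorocebus sabaeus) for cytotoxicity, read by crystal violet staining, with a stated time of 96 h; a higher number here means that more compound is tolerated, a lower number that less compound is tolerated. Compound 1 gives 64000 nM and compound 2 gives 11000 nM, the step between them being a 5.8-fold lower number from compound 1 to compound 2 (0.76 log units; beyond the scatter). Compound 3 gives only a limit, > 100000 nM, so its tolerance is known just as a floor; it is one of the limit of > 100000 nM in this assay, at which 1 of the 3 values shown sits. Set against compound 1 the step reads an at least 1.5-fold higher number from compound 1 to compound 3 (0.19 log units; that floor lies within the scatter), and against compound 2 it reads an at least 9.0-fold higher number from compound 2 to compound 3 (0.95 log units; beyond the scatter).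

Compound 4 `FC(F)(F)c1cccc(NC(=S)Nc2ccc(I)cc2)c1` has not yet been measured. It differs from compound 3 in one place: 4-iodophenyl in place of 2-methylprop-2-en-1-yl on an amide-type nitrogen. Going by the values given here, the step that bears most directly on this change is the one between compound 2 and compound 3. Compound 2 carries a 4-chlorophenyl on that nitrogen, a close relative of the 4-iodophenyl, and an at least 9.0-fold higher number from compound 2 to compound 3 (0.95 log units; beyond the scatter) ran upward when that aryl gave way to the 2-methylprop-2-en-1-yl group. Putting an aryl back in its place is therefore expected to lower the tolerated concentration again, beyond the scatter, and the estimated step is an at least 10-fold lower number from compound 3 to compound 4 (1.00 log units; beyond the scatter). Compound 4 is expected at 10000 nM, within a range of 3000 nM to 40000 nM. That is roughly where compound 2 stands with 11000 nM.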

Compound 4, half-maximal cytotoxic concentration: 9500 nM
The estimate for compound 4 lay 1.1-fold (0.02 log units) above the measured number; the range from low to high includes it.
By their numbers in this assay, from the lowest: compounds 4 and 2 (each within the scatter of the next); then compound 1. At a limit, above all of these: compound 3.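

In this assay, iodo in place of chloro on an aromatic carbon gives a 1.2-fold lower number from compound 2 to compound 4 (0.06 log units; within the scatter), so the two halogens cannot be told apart at this position, and the 4-iodophenyl behaves as a second example of what the 4-chlorophenyl alone had shown. On the amide-type nitrogen, the change from 2-methylprop-2-en-1-yl to 4-iodophenyl gives an at least 10-fold lower number from compound 3 to compound 4 (1.02 log units; beyond the scatter), and the change from 2-fluorophenyl to 4-iodophenyl gives a 6.7-fold lower number from compound 1 to compound 4 (0.83 log units; beyond the scatter), so both of these steps repeat, with a new halogen, the steps already seen for the 4-chlorophenyl. The first of these two steps is only a bound, since the value of compound 3 is a limit: the limit of > 100000 nM in this assay, at which 1 of the 4 values shown sits.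

Going by these compounds, how far compound 3 really lies beyond its limit stays open, and so does where a plain phenyl, a 4-methoxyphenyl, or a longer chain in place of the 2-methylprop-2-en-1-yl would fall on this scale. The 2-fluorophenyl of compound 1 also differs from the 4-iodophenyl of compound 4 in both the halogen and its place on the ring, so the compounds shown do not separate those two changes.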